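Another methylene on the dicarboxy chain: compound 4

The source may hold more compounds than are shown below. What is called first, only, known or untested is meant among the compounds shown, and "the series" means these compounds.

Compound 1 `CC1OC(OC2CCCCC2OCCCCC(C(=O)O)C(=O)O)C(O)C(O)C1O` — in a functional assay on HL-60 cells (Homo sapiens) for inhibition (on this read-out lower numbers stand for stronger inhibition and higher numbers for weaker inhibition), compound 1 gives only a limit, > 5000000 nM.
Compound 2 `CC1OC(OC2CCCCC2OCCCCCCC(C(=O)O)C(=O)O)C(O)C(O)C1O` — in this assay compound 2 gives only a limit, > 5000000 nM.
Compound 3 `CC1OC(OC2CCCCC2OCCCCCCCC(C(=O)O)C(=O)O)C(O)C(O)C1O` — in this assay compound 3 gives only a limit, > 5000000 nM.

All three measured compounds share one core and differ only in the length of the chain that carries the two carboxylic acids. None of them gives a number in this assay: every value sits at the assay limit (the limit of > 5000000 nM in this assay, at which 3 of the 3 values shown sit), so compound 3 stands nowhere in particular, only at that limit. The three steps between them, a step that the two limits leave unreadable from compound 1 to compound 2, a step that the two limits leave unreadable from compound 1 to compound 3 and a step that the two limits leave unreadable from compound 2 to compound 3, are therefore unreadable; their size and direction cannot be told from two limits.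

Compound 4 `CC1OC(OC2CCCCC2OCCCCCCCCC(C(=O)O)C(=O)O)C(O)C(O)C1O` is the next member of this series, differing from compound 3 by 2,2-dicarboxyethyl in place of dicarboxymethyl on a saturated chain carbon, seven bonds along the chain from an oxygen on a saturated carbon. The same kind of lengthening, seen three times already, never moved a value off the limit. The expected step from compound 3 to compound 4 is accordingly a number no higher from compound 3 to compound 4 (the limit leaves the size open). Compound 4 is estimated to show 5000000 nM, within 2000000 nM to 20000000 nM, most likely again as a limit.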

Compound 4, half-maximal inhibitory concentration: > 5000000 nM
Compound 4 ended at the assay's limit; the forecaster's own chance of this, stated with the estimate: 90%; the middle value sits exactly at the limit.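

No step can be read from compound 4 to compound 1, compound 2 or compound 3, since all four compounds stop at the same limit: the limit of > 5000000 nM in this assay, at which 4 of the 4 values shown sit. The compounds shown leave open how strongly, if at all, any of these dicarboxy chains inhibits in this assay, and whether chain length matters.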